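Swapping acetyl for dimethylamino on a pyrazole series

This account rests on a few compounds, and the source may have more. Where it says the series, first, only, none or still open, it means among the compounds named here.

Measured compounds:
- compound 1, `COc1cc(C)cc(-c2c(-c3ccnc(-c4ccc(C(C)=O)cc4)c3)cnn2CC#N)c1`: 95%
- compound 2, `Cc1cc(O)cc(-c2nn(CC#N)cc2-c2ccnc(-c3ccc(N(C)C)cc3)c2)c1`: 104%

Of the compounds shown here, two have been tested in a functional assay on A549 cells (Homo sapiens) for cytotoxicity, read by sulforhodamine B assay, with a stated time of 48 h, tested at 0.001 uM; on this read-out higher numbers stand for a weaker effect at the one concentration tested and lower numbers for a stronger effect. Compound 1 gives 95% in this assay, the lowest of the two numbers shown, and compound 2 gives 104%, a number that lies within the scatter of compound 1, so the two cannot be told apart. Both values say that at this single low concentration neither compound slows the cells noticeably.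

Compound 3, `COc1cc(C)cc(-c2c(-c3ccnc(-c4ccc(N(C)C)cc4)c3)cnn2CC#N)c1`, has not yet been measured. It is built from compound 1 by one change: dimethylamino in place of acetyl on an aromatic carbon. Compound 2 already carries a dimethylamino group on its own phenyl ring and sits at the same level as compound 1, so no basis exists for a step beyond the scatter. The step from compound 1 to compound 3 is therefore expected to be small, a number 5 percentage points higher from compound 1 to compound 3 (within the scatter). Compound 3 is estimated at 100%, with a range from 86% to 114%.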

Compound 3, a percentage reported as activity, at one concentration (the size of the read-out at that concentration, not a potency): 95%
Compound 3: middle estimate off by 5 percentage points, on the high side; measured number inside the range.
By their numbers in this assay, from the lowest: compounds 1, 3 and 2 (each within the scatter of the next).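

Going by these compounds alone, compound 1 and compound 2 differ in more than one place, so this is the first comparison that isolates a single change. In this assay putting 4-(dimethylamino)phenyl in place of 4-acetylphenyl gives no change at the digits printed from compound 1 to compound 3 (within the scatter) and shows that, at this one low concentration, the read-out does not separate these two groups on this aromatic carbon, para to a large group. Nothing available explains this result or links it to any property of either group.

From the compounds shown here alone, whether the two groups would still read alike at higher concentrations remains open, and this single-concentration result gives no measure of potency. Also open, going by these compounds, is how a carboxylic acid or a longer chain ending in an amine would read at this same carbon.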